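A few compounds are considered here, and "the series" means these few. Any claim that something is new, unique, unknown or untested is made for them only; others in the source may bear on it.

Compound 1 `Cc1ncccc1CNc1ncnn1-c1cccc(Cl)c1Cl` gives 11.8 nM in a functional assay for antagonist activity at P2X purinoceptor 7 (Homo sapiens), read by FLIPR and calcium flux; on this read-out higher numbers stand for weaker inhibition and lower numbers for stronger inhibition. Among the compounds with values here, compound 2 `Clc1cccc(-n2ncnc2NCc2cccnc2Oc2cccnc2)c1Cl` gives 13.8 nM in this assay, and the only step joining the two, a 1.2-fold higher number from compound 1 to compound 2 (0.07 log units; within the scatter), leaves compound 1 and compound 2 within the scatter of each other; compound 2 therefore stands beside its single neighbour, with no difference that can be read as a change.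

Compound 3 `Clc1cccc(-n2ncnc2NCc2cccnc2-c2ccsc2)c1Cl` carries the change (thiophen-3-yl in place of (pyridin-3-yl)oxy on an aromatic carbon). Within the data shown here, the one measured step that bears on this position is the exchange of methyl for (pyridin-3-yl)oxy at the same aromatic carbon, a 1.2-fold higher number from compound 1 to compound 2 (0.07 log units; within the scatter), which did not move the number beyond the scatter. Among the measured compounds shown here, that step is the only guide: a six-membered ring with one nitrogen joined through oxygen and a plain methyl gave the same read-out, so a five-membered ring with one sulfur attached directly is expected to leave this assay likewise about where it was, with no step beyond the scatter in either direction.

Compound 3 is therefore expected to give 15 nM in this assay, in a range from 5 nM to 50 nM, which corresponds to an estimated step of a 1.1-fold higher number from compound 2 to compound 3 (0.04 log units; within the scatter).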

Compound 3, half-maximal inhibitory concentration: 15.1 nM
Beside the measured number, compound 3's estimate is 1.0-fold (0.00 log units) below it; the measured number falls inside the stated range.
By their numbers in this assay, from the lowest: compounds 1, 2 and 3 (each within the scatter of the next).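

In this assay, the exchange of (pyridin-3-yl)oxy for thiophen-3-yl gives a 1.1-fold higher number from compound 2 to compound 3 (0.04 log units; within the scatter) and so shows that this aromatic carbon, next to the ring nitrogen, also accepts a five-membered aromatic ring attached directly, with no change that can be read; the oxygen link and the six-membered ring of compound 2 are not required to keep the number in this range. Set against the methyl group, the same thiophen-3-yl gives a 1.3-fold higher number from compound 1 to compound 3 (0.11 log units; within the scatter), which places methyl, (pyridin-3-yl)oxy and thiophen-3-yl within the scatter of one another, so that three groups of different size and ring content cannot be told apart at this position. Nothing is available that would account for this flat read-out.

Whether an amine, a carboxylic acid or a longer alkyl chain on this carbon would move the number beyond the scatter stays open, as every group shown here leaves it in place. On these data alone, the rest of the shared core is the same in all three compounds, so how much the number depends on those parts also remains unknown.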